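The compounds below may be only part of what the source reports. "The series", "measured", "known", "first", "only" and "open" are said of these compounds alone.

Of the compounds shown here, three have been measured in an assay on HEK293 cells for binding affinity to adenosine receptor A2b (Homo sapiens), read by radioligand binding; a higher number here means a weaker inhibitor, a lower number a stronger inhibitor. Compound 1, `Cn1c(=O)n(Cc2ccccc2)c(=O)c2[nH]cnc21`, gives 10200 nM. Compound 2, `CC(=O)OCCn1c(=O)c2c(ncn2C)n(C)c1=O`, gives 8710 nM. Compound 3, `CCCn1c(=O)c2nc(-c3cnccn3)[nH]c2n(CCC)c1=O`, gives 79.6 nM, the lowest of the three numbers and therefore the strongest inhibitor here; its distance from compound 2 and from compound 1 is in each case far beyond the scatter of repeated measurements, so compound 3 stands clearly apart from the other two.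

Compound 4, `CCCn1c(=O)c2nc(-c3cc(O)ccc3O)[nH]c2n(CCC)c1=O`, has not yet been measured. It differs from compound 3 in one place: 2,5-dihydroxyphenyl in place of pyrazin-2-yl on an aromatic carbon. The group that leaves carries no hydrogen-bond donors, while the group that enters brings two, with the count of acceptors unchanged. Going by the values given here, no measured pair shows what this kind of exchange does in this assay, so there is nothing in the data to point firmly in either direction. Because compound 3 already gives 79.6 nM, the expectation is that compound 4 stays in the same region of strong inhibition, with a step from compound 3 to compound 4 of about a 1.3-fold lower number from compound 3 to compound 4 (0.12 log units; within the scatter), which is expected to fall within or only just beyond the scatter. The estimated value for compound 4 is 60 nM, with a likely range from 15 nM to 250 nM.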

Compound 4, inhibition constant: 138 nM
The estimate for compound 4 lay 2.3-fold (0.36 log units) below the measured number; the range from low to high includes it.
By their numbers in this assay, from the lowest: compounds 3 and 4 (each within the scatter of the next); then compounds 2 and 1 (each within the scatter of the next).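

In this assay, replacing pyrazin-2-yl with 2,5-dihydroxyphenyl gives a 1.7-fold higher number from compound 3 to compound 4 (0.24 log units; within the scatter), so the two compounds cannot be told apart. Going by these compounds alone, this is the first direct view of this position, on an aromatic carbon of a five-membered aromatic ring, between two ring nitrogen atoms. In this one pair, a six-membered aromatic ring with two hetero atoms and no hydrogen-bond donors gives way to a larger carbon-only ring with two hydrogen-bond donors, and the measured number stays within the scatter; no measurement shown explains this result.

The compounds shown do not reveal what plain phenyl, a carbon-only ring without hydroxyl groups, would give at this position, leaving the contribution of each hydroxyl group of compound 4 unknown. They also leave open how this position would respond to a ring bearing an amine or a carboxylic acid, and a single pair cannot show whether other exchanges here would stay equally close to compound 3.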